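Diaryl thioureas: cytotoxicity notes ahead of compound 3

The source may hold more compounds than are shown below. What is called first, only, known or untested is meant among the compounds shown, and "the series" means these compounds.

Measured so far:
compound 1 `C=C(C)CNC(=S)Nc1cccc(C(F)(F)F)c1` — > 100000 nM (a limit)
compound 2 `Fc1ccc(NC(=S)Nc2cccc(C(F)(F)F)c2)cc1` — 26000 nM

Within the data shown here, in an ADME assay on BHK cells (Mesocricetus auratus) for cytotoxicity, read by MTT assay, with a stated time of 96 h (a lower number here means that less compound is tolerated, a higher number that more compound is tolerated), compound 2 gives 26000 nM, the only proper number in the set. For compound 1 the read-out is a limit of the assay, > 100000 nM; that is the limit of > 100000 nM in this assay, at which 1 of the 2 values shown sits. Among the measured compounds shown here, the single measured step, an at least 3.8-fold lower number from compound 1 to compound 2 (0.58 log units; beyond the scatter), puts 4-fluorophenyl in place of 2-methylprop-2-en-1-yl on an amide-type nitrogen, and because one end of it is a limit of > 100000 nM in this assay, at which 1 of the 2 values shown sits, its true size is open upward.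

Compound 3 `FC(F)(F)c1cccc(NC(=S)Nc2ccccc2Br)c1` differs from compound 2 by 2-bromophenyl in place of 4-fluorophenyl on an amide-type nitrogen. For the measured compounds named here, no measured step exchanges one aryl group for another; the only step available replaces a chain by a ring and is unbounded on one side, so it bears only loosely on this change. For compound 3 in this assay no step beyond the scatter is therefore expected, and the expected step of a 1.2-fold lower number from compound 2 to compound 3 (0.07 log units; within the scatter) is set near zero with a wide margin. Compound 3 is estimated at 22000 nM, expected to lie between 8000 nM and 70000 nM.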

Compound 3, half-maximal cytotoxic concentration: 59000 nM
Compound 3: the middle estimate sits 2.7-fold (0.43 log units) below what was measured; low and high end bracket the measured number.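

In this assay, an exchange of one aryl group for another on the amide-type nitrogen can now be read directly, and it does register: a 2.3-fold higher number from compound 2 to compound 3 (0.36 log units; beyond the scatter). This modest step shows that the read-out at this position depends on which aryl group is present, even though 4-fluorophenyl and 2-bromophenyl each hold one six-membered aromatic ring of carbon only and the same number of heavy atoms. The comparison of the 2-methylprop-2-en-1-yl chain with the 2-bromophenyl ring gives only a floor, an at least 1.6-fold lower number from compound 1 to compound 3 (0.22 log units; that floor lies within the scatter), and its true size stays unknown, since compound 1 stands at a limit: the limit of > 100000 nM in this assay, at which 1 of the 3 values shown sits.

The compounds shown do not separate the identity of the halogen from its place on the ring, so the step cannot be assigned to either one. From the compounds shown here alone, how the read-out responds to an unsubstituted phenyl group, or to an aryl group carrying an amine or a carboxylic acid, also remains open, as does any change to the trifluoromethyl-bearing side of the shared core.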